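The source may hold more compounds than are shown below. What is called first, only, known or untested is meant among the compounds shown, and "the series" means these compounds.

Measured in a physicochemical assay for solubility, at pH 7.4; a lower number here means a less soluble compound, a higher number a more soluble compound:
- compound 1 `NS(=O)(=O)c1ccc(S(=O)(=O)CCO)c(F)c1`: 3300 ug/mL
- compound 2 `COC(=O)c1cc(S(N)(=O)=O)ccc1S(=O)(=O)CCO`: 33400 ug/mL

For the measured compounds named here, compound 2 holds the higher of the two numbers, and compound 1 is its only neighbour. The next change leads to compound 3 `Nc1cc(S(N)(=O)=O)ccc1S(=O)(=O)CCO`: amino in place of methoxycarbonyl on an aromatic carbon. This puts amino in place of methoxycarbonyl on an aromatic carbon, ortho to a (2-hydroxyethyl)sulfonyl group and meta to a sulfamoyl group.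

Going by the values given here, only one measured step bears on this: a 10-fold higher number from compound 1 to compound 2 (1.01 log units; beyond the scatter), a large step beyond the scatter, with methoxycarbonyl in place of fluoro. Compound 3 gives up that same methoxycarbonyl, so a large step to a lower number is expected in this assay. Among the compounds with values here, no measurement yet compares amino with fluoro, and a single step is thin support. The expected change is a 6.7-fold lower number from compound 2 to compound 3 (0.82 log units; beyond the scatter). For compound 3 the estimate is 5000 ug/mL, with an expected range from 1500 ug/mL to 17000 ug/mL.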

Compound 3, solubility: 13200 ug/mL
For compound 3 the middle estimate is 2.6-fold (0.42 log units) below the measured one, within the range that was stated.
By their numbers in this assay, from the lowest: compound 1; then compound 3; then compound 2.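

In this assay the aromatic carbon ortho to a (2-hydroxyethyl)sulfonyl group and meta to a sulfamoyl group now carries three substituents, and replacing methoxycarbonyl with amino gives a 2.5-fold lower number from compound 2 to compound 3 (0.40 log units; beyond the scatter) without a return to the fluoro level. Amino also differs from fluoro on this carbon, with a 4.0-fold higher number from compound 1 to compound 3 (0.60 log units; beyond the scatter) in the same read-out, so the three substituents give three separate levels and methoxycarbonyl is not the only one above fluoro. Nothing available accounts for this order.

Open, as far as these compounds go, is where a carboxylic acid, a methylamino group or an acetamido group on this carbon would fall relative to these three. Also open, from the compounds shown here alone, is whether these steps keep their size when a longer chain replaces the 2-hydroxyethyl chain on the sulfonyl group.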